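The source may hold more compounds than are shown below. What is called first, only, known or untested is meant among the compounds shown, and "the series" means these compounds.

For the measured compounds named here, compound 3 `OC(CNc1[nH]cnc2ncnc1-2)CN1CCN(C(c2ccc(F)cc2)c2ccc(F)cc2)CC1` gives the lowest of the three numbers known so far in a functional assay on muscle tissue (Mustela putorius furo) (a higher number here means a larger maximal response, a lower number a smaller maximal response), namely 86%. Going by the values given here, its nearest neighbour is compound 1 `OC(CSc1ncnc2[nH]cnc12)CN1CCN(C(c2ccc(F)cc2)c2ccc(F)cc2)CC1`, which in this assay reaches 189%; the gap is the single measured step, a number 103 percentage points lower from compound 1 to compound 3 (beyond the scatter). Compound 2 `CC(=O)OC(CSc1[nH]cnc2ncnc1-2)CN1CCN(C(c2ccc(F)cc2)c2ccc(F)cc2)CC1` is the acetylated counterpart of the hydroxy compound and stands furthest away; in this assay compound 2 gives 248%.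

Compound 4 `CC(=O)OC(CNc1[nH]cnc2ncnc1-2)CN1CCN(C(c2ccc(F)cc2)c2ccc(F)cc2)CC1` is built from compound 3 by one change: acetyl in place of hydrogen on an oxygen on a saturated carbon. Among the compounds with values here, no measured step bears on this change in the nitrogen-linked series. Within the data shown here, the only guide is the pair compound 1 and compound 2, whose values in this assay show the acetylated member above the hydroxy member by a margin well beyond the usual scatter. On that basis the writer expects a step upward of moderate size, a number 49 percentage points higher from compound 3 to compound 4 (beyond the scatter), for compound 4. The estimate for compound 4 in this assay is therefore 135%, with a range from 90% to 190%.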

Compound 4, largest response reached (reported as maximum), in percent of the reference or control that the assay uses: 45%
Compound 4: the middle estimate sits 90 percentage points above what was measured; measured number outside the range, below it.
By their numbers in this assay, from the lowest: compound 4; then compound 3; then compound 1; then compound 2.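

In this assay, hydroxy to acetoxy does not move the number the same way in the two series: the nitrogen-bearing pair shows a number 41 percentage points lower from compound 3 to compound 4 (beyond the scatter), whereas among the sulfur-bearing compounds, compound 1 gives 189% and compound 2 gives 248%. Replacing the sulfur-bearing group with the nitrogen-bearing group lowers the number with acetoxy present as well, a number 203 percentage points lower from compound 2 to compound 4 (beyond the scatter), and that step is wider than the one with hydroxy present, a number 103 percentage points lower from compound 1 to compound 3 (beyond the scatter), so the effects of the two changes do not simply add. No supporting evidence is available to explain this reversal.

Going by these compounds, it remains open whether a propionyl or benzoyl ester, or a methyl ether, on this oxygen would follow the acetyl group in either series. On these data alone, how an oxygen-linked group would behave in place of the sulfur-bearing and nitrogen-bearing groups also remains open.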